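The source may hold more compounds than are shown below. What is called first, only, known or untested is meant among the compounds shown, and "the series" means these compounds.

Compound 1 `Cc1cccc(C)c1NC(=O)CSc1snnc1-c1ccc(Br)cc1Br` is the reference point of this set. In an ADME assay on MT4 cells (Homo sapiens) for cytotoxicity, read by MTT assay, with a stated time of 5 days (a lower number here means that less compound is tolerated, a higher number that more compound is tolerated), compound 1 gives >= 198000 nM, which is a limit of the assay rather than a measured number. Compound 2 `CC(=O)c1ccc(NC(=O)CSc2snnc2-c2ccc(Br)cc2Br)c(Br)c1` gives > 206000 nM in this assay, again only a limit. Compound 3 `COC(=O)c1ccsc1NC(=O)CSc1snnc1-c1ccc(Br)cc1Br` gives > 227000 nM in this assay, also a limit. Going by the values given here, the one measured step that touches compound 1, a step that the two limits leave unreadable from compound 1 to compound 3, is therefore unreadable, and all three values shown sit at limits, so compound 1 can be placed only as tolerated up to the highest concentration tested, with no ordering among the three.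

Compound 4 `O=C(CSc1snnc1-c1ccc(Br)cc1Br)Nc1ccccc1Br` differs from compound 1 in one place: 2-bromophenyl in place of 2,6-dimethylphenyl on an amide-type nitrogen. Among the compounds with values here, no measured step bears on this change, and the unreadable step from compound 1 to compound 3 gives no size to lean on. The expected step that the limit leaves unreadable from compound 1 to compound 4 is therefore none beyond the scatter, with compound 4 expected to remain tolerated across the tested range. Compound 4 is estimated at 200000 nM in this assay, within a range from 100000 nM to 400000 nM, most probably reported again as a limit.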

Compound 4, half-maximal cytotoxic concentration: > 221000 nM
Compound 4 gave a limit, no number; the forecaster's own chance of this, stated with the estimate: 85%; middle value at least 1.1-fold (0.04 log units) from the limit.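

Compound 4 gives > 221000 nM, which is a limit and not a number. Going by these compounds alone, no step to compound 4 from compound 1, compound 2 or compound 3 can be read: all four values are limits. The compounds shown leave open the half-maximal cytotoxic concentration of each compound in this assay, and whether the changes among them shift it at all.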